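Trading a Bromobenzyl Arm for a Propyl Chain

The compounds below may be only part of what the source reports. "The series", "measured", "known", "first", "only" and "open" are said of these compounds alone.

Compound 1 `Cc1cc(Nc2cc(-c3ccccc3)[nH]n2)n2nc(SCc3cccc(Br)c3)nc2n1` stands second highest of three measured numbers in a functional assay on MGC-803 cells (Homo sapiens) for inhibition, read by MTT assay, with a stated time of 72 h (a lower number here means a stronger inhibitor, a higher number a weaker inhibitor), where compound 1 gives 4820 nM. Compound 2 `Cc1cc(Nc2cc(C(C)(C)C)[nH]n2)n2nc(SCc3ccc(Br)cc3)nc2n1` gives 5620 nM, within the scatter of compound 1, while compound 3 `Cc1cc(Nc2ccn(Cc3nc(C)c4ccccc4n3)n2)n2nc(SCc3ccc(Br)cc3)nc2n1` gives 960 nM, a clearly lower number than compound 1. Among the compounds with values here, compound 4 `CCCSc1nc2nc(C)cc(Nc3cc(-c4ccccc4)[nH]n3)n2n1` has not yet been measured and differs from compound 1 in one place: ethyl in place of 3-bromophenyl on a saturated chain carbon bound to a sulfur No measured pair shows this change, so its size cannot be read from the data. All three measured compounds carry a bromobenzyl group; compound 4 does not, and a weaker result, beyond the scatter, is expected. The expected step is a 2.5-fold higher number from compound 1 to compound 4 (0.40 log units; beyond the scatter). Compound 4 is estimated to give 12000 nM, within 4000 nM to 40000 nM.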

Compound 4, half-maximal inhibitory concentration: 12600 nM
Estimate against measurement, compound 4: 1.1-fold (0.02 log units) below, within the range that was stated.
By their numbers in this assay, from the lowest: compound 3; then compounds 1 and 2 (each within the scatter of the next); then compound 4.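

Replacing the 3-bromobenzyl group on the sulfur with propyl gives a 2.6-fold higher number from compound 1 to compound 4 (0.42 log units; beyond the scatter) in this assay, a first view of this position, since all three earlier compounds carry a bromobenzyl group. The step is modest, so the number does depend on this group, yet activity in this assay does not vanish without the ring and bromine. Nothing measured here explains the step. On these data alone, whether the ring, the bromine or the chain matters most stays open. A plain benzyl group, a longer chain such as hexyl, or a chain ending in an amine would help separate these.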